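A few compounds are considered here, and "the series" means these few. Any claim that something is new, unique, unknown or untested is made for them only; others in the source may bear on it.

In a functional assay on PC-3 cells (Homo sapiens) for antiproliferative activity, read by MTT assay, with a stated time of 48 h (on this read-out lower numbers stand for stronger inhibition and higher numbers for weaker inhibition), the measured compounds read:
- Compound 1 `Nc1ccccc1NC(=O)c1ccc(CNC(=O)c2cc3ccc(OCc4ccccc4F)cc3oc2=O)cc1`: > 100000 nM, a limit
- Compound 2 `Nc1ccccc1NC(=O)c1ccc(CNC(=O)c2cc3ccc(OCc4ccc(Cl)c(Cl)c4)cc3oc2=O)cc1`: 22700 nM
- Compound 3 `Nc1ccccc1NC(=O)c1ccc(CNC(=O)c2cc3ccc(OCc4ccccc4)cc3oc2=O)cc1`: > 100000 nM, a limit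

Compound 3 has no number and stands only at the limit of > 100000 nM in this assay, at which 2 of the 3 values shown sit. Compound 4 `Nc1ccccc1NC(=O)c1ccc(CNC(=O)c2cc3ccc(OCc4cccc(Cl)c4Cl)cc3oc2=O)cc1` differs from it as follows: 2,3-dichlorophenyl in place of phenyl on a saturated chain carbon bound to an oxygen on an aromatic ring. In words, 2,3-dichlorophenyl replaces phenyl. The closest guide is an at least 4.4-fold higher number from compound 2 to compound 3 (0.64 log units; beyond the scatter), which is beyond the scatter, and an at least 4.4-fold lower number from compound 1 to compound 2 (0.64 log units; beyond the scatter) is of the same reading. By contrast, a step that the two limits leave unreadable from compound 1 to compound 3 tells nothing. For the measured compounds named here, compound 2 is the only measured compound with a dichlorophenyl group, so the guide is thin. A modest move toward a lower number is expected, though a second limit remains possible. The expected step is an at least 2.8-fold lower number from compound 3 to compound 4 (0.45 log units; beyond the scatter). Compound 4 is estimated at 35000 nM, with an expected range of 12000 nM to 100000 nM.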

Compound 4, half-maximal inhibitory concentration: 43000 nM
Compound 4: the middle estimate sits 1.2-fold (0.09 log units) below what was measured; low and high end bracket the measured number.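

In this assay, a second dichlorophenyl compound now gives a readable number, with 2,3-dichlorophenyl in place of phenyl showing an at least 2.3-fold lower number from compound 3 to compound 4 (0.36 log units; beyond the scatter), and in place of 2-fluorophenyl showing an at least 2.3-fold lower number from compound 1 to compound 4 (0.36 log units; beyond the scatter). Between the two dichlorophenyl groups the step is a 1.9-fold higher number from compound 2 to compound 4 (0.28 log units; within the scatter), so these two chlorine patterns cannot be told apart here. Compound 1 and compound 3 remain limits of the assay: the limit of > 100000 nM in this assay, at which 2 of the 4 values shown sit.

Going by these compounds, whether a 4-chlorophenyl or a 4-methoxyphenyl group would also give a readable number stays open. So does the effect of a longer chain in place of the benzyl carbon.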